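The source may hold more compounds than are shown below. What is called first, only, known or untested is meant among the compounds shown, and "the series" means these compounds.

Of the compounds shown here, three built on one shared core have so far been measured in an ADME assay for pharmacokinetics, read by LC-MS, in phosphate buffer, with a stated time of 72 h, at pH 7.4, tested at 250 uM; on this read-out lower numbers stand for a shorter-lived compound and higher numbers for a longer-lived compound. Compound 1 `C=CS(=O)(=O)c1cc(C(F)(F)F)cc(C(F)(F)F)c1` carries a vinylsulfonyl group; in this assay compound 1 gives < 0.017 h, which is a limit of the assay rather than a number. Compound 2 `C=Cc1cc(C(F)(F)F)cc(C(F)(F)F)c1` carries a vinyl group in its place; in this assay compound 2 gives > 50 h, also a limit. Compound 3 `C#Cc1cc(C(F)(F)F)cc(C(F)(F)F)c1` carries an ethynyl group; in this assay compound 3 gives > 50 h, again a limit. Compound 3 therefore stands at the long-lived end of what has been seen, and its value and that of compound 2 cannot be told apart. The step of an at least 2900-fold higher number from compound 1 to compound 2 (3.46 log units; beyond the scatter) and the step of an at least 2900-fold higher number from compound 1 to compound 3 (3.46 log units; beyond the scatter) were both large. Compound 4 `O=C(CBr)c1cc(C(F)(F)F)cc(C(F)(F)F)c1` is the next compound: (bromomethyl)carbonyl in place of ethynyl on an aromatic carbon. Neither measured step exchanges an ethynyl for a (bromomethyl)carbonyl, so they bear on this change only loosely; they do show that one group on this core can move the half-life from the lowest reading to the highest. The expected step is an at least 2.5-fold lower number from compound 3 to compound 4 (0.39 log units; beyond the scatter), toward a shorter-lived compound. Compound 4 is estimated at 20 h, within 2 h to 50 h.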

Compound 4, half-life: < 0.017 h
Compound 4: no number, only a limit; the forecaster's own chance of this, stated with the estimate: 25%; middle value at least 1100-fold (3.07 log units) away from the limit.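

In this assay, putting (bromomethyl)carbonyl at this position gives an at least 2900-fold lower number from compound 3 to compound 4 (3.46 log units; beyond the scatter), and the same group gives an at least 2900-fold lower number from compound 2 to compound 4 (3.46 log units; beyond the scatter). Vinylsulfonyl is therefore not the only group on the shared core that reaches the short-lived end of the read-out, as a group with a carbonyl and a bromine does so too, whereas vinyl and ethynyl both sit at the long-lived end. The true sizes of these steps stay hidden, and the step between compound 1 and compound 4 cannot be read, because both compounds sit at the same limit: the limit of < 0.017 h in this assay, at which 2 of the 4 values shown sit.

This change brings in the carbonyl and the bromine together, so the compounds shown do not tell which of the two goes with the drop. As far as these compounds go, whether an acetyl group or a (chloromethyl)carbonyl at this position would give a half-life between the two limits also stays open.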